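The source may report more compounds than this note shows. Statements on the series, on what has been measured and on what is new or still open speak of the compounds shown alone.

Three carboxylic acids built on one shared core have been followed in an in vivo ADME assay on the whole organism (plasma, strain Sprague-Dawley) for pharmacokinetics, with Rattus norvegicus as the target; on this read-out higher numbers stand for fast clearance and lower numbers for slow clearance. In this test, compound 1 `Cc1cc(CCC(=O)O)ccc1-c1noc(-c2ccc(OC(C)C)c(C#N)c2)n1` gives 2.3 mL/min/kg, and compound 2 `Cc1cc([C@@H]2C[C@H]2C(=O)O)ccc1-c1noc(-c2ccc(OC(C)C)c(C(F)(F)F)c2)n1` gives 2.4 mL/min/kg. These two values lie within the scatter of each other, so compound 2 stands level with compound 1. Compound 3 `Cc1cc([C@@H]2C[C@H]2C(=O)O)ccc1-c1noc(-c2ccc(OC(C)C)c(C#N)c2)n1` gives "not determined" (no result reported); 3.4 mL/min/kg; 1 mL/min/kg (3 entries), and the several entries of compound 3 in this assay, "not determined" (no result reported); 3.4 mL/min/kg; 1 mL/min/kg (3 entries) are a reminder that a single reading of this kind is only a loose guide.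

Compound 4 `Cc1cc(CC(C)C(=O)O)ccc1-c1noc(-c2ccc(OC(C)C)c(C(F)(F)F)c2)n1` has not yet been measured. It differs from compound 2 in one place: 2-carboxypropyl in place of 2-carboxycyclopropyl on an aromatic carbon. In words, 2-carboxypropyl stands in place of 2-carboxycyclopropyl on an aromatic carbon, so the three-membered ring is gone. Among the measured compounds shown here, no measured pair isolates this change. Still, compound 1 also carries its acid on an open chain and gives 2.3 mL/min/kg, so no step beyond the scatter is expected in this assay, only a slight drift toward faster clearance. The expected change is a 1.3-fold higher number from compound 2 to compound 4 (0.10 log units; within the scatter). For compound 4 the estimate is 3 mL/min/kg, with an expected range of 1.2 mL/min/kg to 7 mL/min/kg.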

Compound 4, clearance: 7 mL/min/kg
Compound 4: the middle estimate sits 2.3-fold (0.37 log units) below what was measured; the measured number falls inside the stated range.
By their numbers in this assay, from the lowest: compounds 1 and 2 (each within the scatter of the next); then compound 4.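

Among the compounds shown here, at this position, on an aromatic carbon para to a large group, the earlier compounds offered no direct test of the three-membered ring, and opening 2-carboxycyclopropyl to 2-carboxypropyl now gives a measurable move toward faster clearance in this assay: a 2.9-fold higher number from compound 2 to compound 4 (0.46 log units; beyond the scatter). The two groups hold the same count of heavy atoms, but the change removes both the ring and the two defined stereocentres, and this one pair cannot separate those two differences. The step is modest, and repeat readings of a related acid spread widely enough to call for caution: the several entries of compound 3 in this assay, "not determined" (no result reported); 3.4 mL/min/kg; 1 mL/min/kg (3 entries)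

As far as these compounds go, it remains open whether the same change would give a similar step with a nitrile in place of the trifluoromethyl group. Also open, from the compounds shown here alone, is how clearance would respond to a longer chain carrying the carboxylic acid, or to a primary amide in place of that acid.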